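Methylating a Phenol on Two Different Aryl Groups

A few compounds are considered here, and "the series" means these few. Any claim that something is new, unique, unknown or untested is made for them only; others in the source may bear on it.

Compound 1 `N#CC1=C(N)N(c2ccc(S(N)(=O)=O)cc2)C2=C(C(=O)CCC2)C1c1ccc(O)cc1` gives 100% in a functional assay on Ehrlich cells (Mus musculus) for antiproliferative activity, read by trypan blue exclusion, with a stated time of 2 h, tested at 50 ug/mL; a lower number here means a weaker effect, a higher number a stronger effect of the compound at the concentration tested. Compound 2 `COc1ccc(C2C(C#N)=C(N)N(c3ccc(S(N)(=O)=O)cc3)C3=C2C(=O)CCC3)cc1` differs by methyl in place of hydrogen on an oxygen on an aromatic ring and gives 90%, so a number 10 percentage points lower from compound 1 to compound 2 (within the scatter). Compound 3 `N#CC1=C(N)N(c2ccc(S(N)(=O)=O)cc2)C2=C(C(=O)CCC2)C1c1c(O)ccc2ccccc12` carries the change 2-hydroxynaphthalen-1-yl in place of 4-hydroxyphenyl on a saturated ring carbon and gives 5%, which makes a number 95 percentage points lower from compound 1 to compound 3 (beyond the scatter) and, against compound 2, a number 85 percentage points lower from compound 2 to compound 3 (beyond the scatter). Compound 4 `COc1ccc2ccccc2c1C1C(C#N)=C(N)N(c2ccc(S(N)(=O)=O)cc2)C2=C1C(=O)CCC2` is not yet measured; it differs from compound 3 by methyl in place of hydrogen on an oxygen on an aromatic ring, the same change as that between compound 1 and compound 2, made at the same kind of place. In this assay the earlier methylation made a step within the scatter, so the same is expected here. The step expected is no change at the digits printed from compound 3 to compound 4 (within the scatter), judged by a number 10 percentage points lower from compound 1 to compound 2 (within the scatter). For compound 4 the expected value is 5%, between 0% and 20%.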

Compound 4, a percentage reported as activity, at one concentration (the size of the read-out at that concentration, not a potency): 70%
Compound 4: the middle estimate sits 65 percentage points below what was measured; measured number above the stated range.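

Methylating the phenol does not carry over from one core to the other in this assay, since the two steps differ: the same change on two cores in this assay, a number 10 percentage points lower (within the scatter) from compound 1 to compound 2 and a number 65 percentage points higher (beyond the scatter) from compound 3 to compound 4, 75 percentage points apart, beyond the scatter of two such steps

On the naphthalene-bearing core the methyl gives a number 65 percentage points higher from compound 3 to compound 4 (beyond the scatter), yet the 2-methoxynaphthalen-1-yl group does not fully match the two phenyl-bearing compounds, with a number 20 percentage points lower from compound 2 to compound 4 (beyond the scatter) and a number 30 percentage points lower from compound 1 to compound 4 (beyond the scatter). So the outcome of this change depends on the aryl group that carries it, but two pairs do not explain why or give a rule for any third aryl group.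

From the compounds shown here alone, it remains open whether an ethyl group on that oxygen, or an amine in place of the oxygen, would behave like the methyl on either aryl group. With a read-out at one concentration, these results tell only of a stronger or weaker effect at that concentration.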